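Replacing a chloroaryl with a pyrazolylmethyl on the hydroxyacyl arm

The compounds below may be only part of what the source reports. "The series", "measured", "known", "first", "only" and "open" are said of these compounds alone.

The series is read in an ADME assay on liver for metabolic stability, with Liver microsome (Homo sapiens) as the target, read by LC-MS, using microsomes; on this read-out higher numbers stand for fast clearance and lower numbers for slow clearance. Compound 1 `O=C(NCc1cc(Cl)ccc1-n1cnnn1)[C@@H]1[C@H]2C[C@H]2CN1C(=O)[C@H](O)c1ccccc1` gives 61 mL.min-1.g-1. Among the measured compounds shown here, compound 2 `O=C(NCc1cc(Cl)ccc1-n1cnnn1)[C@@H]1[C@H]2C[C@H]2CN1C(=O)[C@H](O)Cc1ccccc1` gives 96 mL.min-1.g-1, and the one measured step, a 1.6-fold higher number from compound 1 to compound 2 (0.20 log units; within the scatter), changes the same saturated chain carbon that carries the hydroxyl. Compound 3 `O=C(NCc1cc(Cl)ccc1-n1cnnn1)[C@@H]1C[C@@H]2C[C@@H]2N1C(=O)[C@H](O)c1cccc(Cl)c1` is reported only as a limit of the assay, > 500 mL.min-1.g-1, so its value is not a number; it sits at the limit of > 500 mL.min-1.g-1 in this assay, at which 1 of the 3 values shown sits, the fast end of the three values shown. Compound 4 `O=C(NCc1cc(Cl)ccc1-n1cnnn1)[C@@H]1C[C@@H]2C[C@@H]2N1C(=O)[C@H](O)Cn1cccn1` keeps the core of compound 3 and differs from it in one place: (1H-pyrazol-1-yl)methyl in place of 3-chlorophenyl on a saturated chain carbon bound to a carbonyl carbon and an oxygen on a saturated carbon. For the measured compounds named here, no measured step covers this exchange, and the single step between compound 1 and compound 2 is within the scatter, so the numbers give no direct guide to direction. Since compound 3 is only a limit, the step to compound 4 cannot be sized from data; the account simply expects a lower number, an at least 3.3-fold lower number from compound 3 to compound 4 (0.52 log units; beyond the scatter). Compound 4 is therefore estimated at 150 mL.min-1.g-1, within 50 mL.min-1.g-1 to 450 mL.min-1.g-1.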

Compound 4, intrinsic clearance in microsomes: < 12 mL.min-1.g-1
Compound 4 gave a limit, no number; the forecaster's own chance of this, stated with the estimate: 20%; at least 12-fold (1.09 log units) between middle value and limit.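

Among the compounds shown here, on the earlier core, the only exchange at this saturated chain carbon, bound to a carbonyl carbon and an oxygen on a saturated carbon, stayed within the scatter, whereas this exchange shows that the position can shift this assay far beyond it, with an at least 41-fold lower number from compound 3 to compound 4 (1.61 log units; beyond the scatter). The result for compound 4 is a limit of the assay, not a number: the limit of < 12 mL.min-1.g-1 in this assay, at which 1 of the 4 values shown sits. On these data alone, the result for compound 3 is also a limit of the assay, so the true size of the step remains unknown: the limit of > 500 mL.min-1.g-1 in this assay, at which 1 of the 4 values shown sits.

Left open is whether the step belongs to the loss of the chlorine, the change of aromatic ring or the methyl link, as all three change together here. Also open, as far as these compounds go, is how a pyridine ring or an amine at this position would read in this assay.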